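The source may report more compounds than this note shows. Statements on the series, on what has been measured and on what is new or still open speak of the compounds shown alone.

Measured so far in a functional assay on a cell-free system (plasma, Homo sapiens), with a stated time of 3 min; a higher number here means a weaker inhibitor, a lower number a stronger inhibitor:
- compound 1 `CC(C)(C)[C@@H](O)C(=O)N1C[C@@H]2C[C@@H]2[C@H]1C(=O)NCc1cc(Cl)ccc1-n1cnnn1`: 570 nM
- compound 2 `O=C(NCc1cc(Cl)ccc1-n1cnnn1)[C@@H]1C[C@H]2C[C@H]2N1C(=O)[C@H](O)c1ccccc1`: 680 nM

Compound 1, at 570 nM, stands within the scatter of compound 2, at 680 nM, so this assay does not separate the two.

The step now followed leads from compound 1 to compound 3 `O=C(NCc1cc(Cl)ccc1-n1cnnn1)[C@@H]1[C@H]2C[C@H]2CN1C(=O)[C@H](O)Cc1ccccc1`. The change is benzyl in place of tert-butyl on a saturated chain carbon bound to a carbonyl carbon and an oxygen on a saturated carbon. Cut one bond further out, the same difference reads 1-hydroxy-2,2-dimethylpropyl to 1-hydroxy-2-phenylethyl.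

Among the compounds with values here, no pair of measured compounds isolates this change, so the data give no direct size for it, and the expectation is correspondingly loose. No shift beyond the scatter is expected in this assay, and no direction is favoured. The expected 1.1-fold higher number from compound 1 to compound 3 (0.06 log units; within the scatter) therefore stays small. For compound 3 the estimated value is 650 nM, with an expected range of 200 nM to 2000 nM.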

Compound 3, half-maximal inhibitory concentration: 1200 nM
The estimate for compound 3 lay 1.8-fold (0.27 log units) below the measured number; measured number inside the range.
By their numbers in this assay, from the lowest: compounds 1, 2 and 3 (each within the scatter of the next, the first and the last beyond it).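

Within the data shown here, this is the first step at this position that can be read in this assay: benzyl in place of tert-butyl on a saturated chain carbon bound to a carbonyl carbon and an oxygen on a saturated carbon gives a 2.1-fold higher number from compound 1 to compound 3 (0.32 log units; beyond the scatter) and so counts as a modest step, just past what repeated measurements would blur. The position therefore responds to the group it carries, with the tert-butyl compound holding the lower number, yet bringing in a six-membered aromatic ring of carbon only leaves the inhibitor within a modest distance of its parent. Nothing measured here bears on why the number rises with this change.

The compounds shown leave open whether cyclohexylmethyl in this place would stay with tert-butyl or go with benzyl, and so whether the aromatic ring itself matters, and what an amine or a carboxylic acid on that chain would do. They also leave open whether the step keeps its size on the core of compound 2, which differs from compound 1 and compound 3 in more than one place.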